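The source may report more compounds than this note shows. Statements on the series, on what has been measured and on what is new or still open speak of the compounds shown alone.

Measured compounds:
Compound 1, `CCN1CCN(CCCn2cnc3c(N4CCN(CC)CC4)nc(NCc4ccccc4)nc32)CC1`: 140 nM
Compound 2, `CCN1CCN(CCCn2cnc3c(N4CCN(CC)CC4)nc(N)nc32)CC1`: 260 nM

In an assay on HEK293 cells for antagonist activity at Toll-like receptor 9 (Homo sapiens), read by spectrophotometry (a lower number here means a stronger inhibitor, a higher number a weaker inhibitor), compound 2 gives 260 nM and compound 1 gives 140 nM; the gap between them, a 1.9-fold higher number from compound 1 to compound 2 (0.27 log units; within the scatter), lies within the scatter. Compound 3, `CCN1CCN(CCCn2cnc3c(N4CCN(CC)CC4)nc(N4CCCC4)nc32)CC1`, is not yet measured. It differs from compound 2 by pyrrolidin-1-yl in place of amino on an aromatic carbon. Among the measured compounds shown here, the only step that bears on this change is the one already seen at the same amino group, a 1.9-fold higher number from compound 1 to compound 2 (0.27 log units; within the scatter), which stayed within the scatter. A step of similar modest size, in no sure direction, is therefore expected in this assay. Compound 3 is expected to give 200 nM, within 70 nM to 600 nM. The expected step is a 1.3-fold lower number from compound 2 to compound 3 (0.11 log units; within the scatter).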

Compound 3, half-maximal inhibitory concentration: 500 nM
The estimate for compound 3 lay 2.5-fold (0.40 log units) below the measured number; the measured number falls inside the stated range.
By their numbers in this assay, from the lowest: compounds 1, 2 and 3 (each within the scatter of the next, the first and the last beyond it).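

In this assay, pyrrolidin-1-yl in place of amino gives a 1.9-fold higher number from compound 2 to compound 3 (0.28 log units; within the scatter), so this single change stays within the scatter. Set against the benzylamino group, the same pyrrolidin-1-yl gives a 3.6-fold higher number from compound 1 to compound 3 (0.55 log units; beyond the scatter), the first step at this aromatic carbon to pass beyond the scatter, though it remains modest. Nothing available accounts for this difference. The compounds shown leave open how a dimethylamino, morpholin-4-yl or phenethylamino group on this carbon would compare. They also leave open whether these steps would hold with a group such as piperidin-1-yl in place of the 4-ethylpiperazin-1-yl group.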